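Swapping 5-methylthiophen-2-yl for pyridin-4-yl in compound 1

The source may report more compounds than this note shows. Statements on the series, on what has been measured and on what is new or still open speak of the compounds shown alone.

compound 1 (`COc1cc(NCc2ccc(C)s2)ccc1-c1cnco1`): 34400 nM
compound 2 (`COc1cc(/N=C/c2cccs2)ccc1-c1cnco1`): > 100000 nM (a limit)
compound 3 (`COc1ccc(-c2cnco2)cc1NCc1cccs1`): > 100000 nM (a limit)

For the measured compounds named here, in an ADME assay on Huh-7 cells (Homo sapiens) for cytotoxicity, read by MTT assay, with a stated time of 96 h (a lower number here means that less compound is tolerated, a higher number that more compound is tolerated), compound 1, at 34400 nM (a true number), is the only compound with a measured number. Compound 2 and compound 3 report only a limit (the limit of > 100000 nM in this assay, at which 2 of the 3 values shown sit).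

Compound 4 (`COc1cc(NCc2ccncc2)ccc1-c1cnco1`) differs from compound 1 in one place (pyridin-4-yl in place of 5-methylthiophen-2-yl on a saturated chain carbon bound to a nitrogen on an aromatic ring): pyridin-4-yl in place of 5-methylthiophen-2-yl on a saturated chain carbon bound to a nitrogen on an aromatic ring. Going by the values given here, no two measured compounds differ in only one place, so no measured step sets the size of this change. Among the compounds with values here, the only hint is compound 3, which reports the limit > 100000 nM in this assay and is a limit only. A small expected move toward the more tolerated side, perhaps none beyond the scatter, is the estimated step of a 1.7-fold higher number from compound 1 to compound 4 (0.24 log units; within the scatter) here. For compound 4 the estimated value is 60000 nM with an expected range from 20000 nM to 100000 nM in this assay.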

Compound 4, half-maximal cytotoxic concentration: 72200 nM
Compound 4: the middle estimate sits 1.2-fold (0.08 log units) below what was measured; the range from low to high includes it.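

In this assay, changing (5-methylthiophen-2-yl)methyl to (pyridin-4-yl)methyl gives a 2.1-fold higher number from compound 1 to compound 4 (0.32 log units; beyond the scatter), the only measured size for a change at this position. The step is modest, but it shows that the group on this saturated chain carbon can shift how much compound the cells tolerate. Compound 4 also still gives a true number rather than a limit.

From the compounds shown here alone, this one swap changes the ring and removes the methyl together, so the share of each stays open. Going by these compounds, how a phenyl or a pyridin-3-yl group would read here in this assay also stays open.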